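Moving bromine and fluorine around the sulfonamide aryl ring

This account rests on a few compounds, and the source may have more. Where it says the series, first, only, none or still open, it means among the compounds named here.

Three arylsulfonamides built on a shared core have been measured in an assay on isolated protein for binding affinity to 5-hydroxytryptamine receptor 6 (Homo sapiens); a lower number here means a stronger inhibitor, a higher number a weaker inhibitor. Compound 1 `COc1ccc(Cl)cc1NS(=O)(=O)c1ccc(OC)c(N2CCNCC2)c1` gives 1.26 nM, compound 2 `COc1ccc(S(=O)(=O)Nc2ccc(C)cc2Br)cc1N1CCNCC1` gives 7.94 nM, and compound 3 `COc1ccc(S(=O)(=O)Nc2c(F)cc(Br)cc2F)cc1N1CCNCC1` gives 158 nM, the highest number of the three, beyond the scatter from both others. Among the compounds with values here, the steps so far all exchange the aryl group on the sulfonamide nitrogen: a 6.3-fold higher number from compound 1 to compound 2 (0.80 log units; beyond the scatter), a 130-fold higher number from compound 1 to compound 3 (2.10 log units; beyond the scatter) and a 20-fold higher number from compound 2 to compound 3 (1.30 log units; beyond the scatter), so this position has moved the numbers modestly to strongly. Compound 4 `COc1ccc(S(=O)(=O)Nc2cc(Br)cc(Br)c2F)cc1N1CCNCC1` differs from compound 3 in the same place: 3,5-dibromo-2-fluorophenyl in place of 4-bromo-2,6-difluorophenyl on a sulfonamide nitrogen. Compound 2, also carrying a bromine on that ring, gives 7.94 nM, while compound 3 with its bromine and two fluorines gives 158 nM, so the change is expected to lower the number, though not back to the level of compound 1. Compound 4 is therefore expected to give 40 nM, within 10 nM to 160 nM, a step of a 4.0-fold lower number from compound 3 to compound 4 (0.60 log units; beyond the scatter).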

Compound 4, inhibition constant: 2.51 nM
Compound 4: middle estimate off by 16-fold (1.20 log units), on the high side; measured number below the stated range.
By their numbers in this assay, from the lowest: compounds 1 and 4 (each within the scatter of the next); then compound 2; then compound 3.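

In this assay the exchange of 4-bromo-2,6-difluorophenyl for 3,5-dibromo-2-fluorophenyl on the sulfonamide nitrogen gives a 63-fold lower number from compound 3 to compound 4 (1.80 log units; beyond the scatter), so this position responds strongly even between two aryl groups of equal heavy-atom count, both carrying only halogens. The new group also compares well with 2-bromo-4-methylphenyl, with a 3.2-fold lower number from compound 2 to compound 4 (0.50 log units; beyond the scatter), and the comparison with 5-chloro-2-methoxyphenyl gives a 2.0-fold higher number from compound 1 to compound 4 (0.30 log units; within the scatter), so a ring with no methoxy group can match compound 1 in this assay. Nothing available here accounts for these differences.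

The two halogenated groups differ both in their number of bromines and in where the halogens sit, and the compounds shown do not separate these two changes. As far as these compounds go, how an amine or a nitrile on this aryl ring would compare also remains open.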